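The compounds below may be only part of what the source reports. "The series", "measured", "known", "first", "only" and "open" are said of these compounds alone.

Measured compounds in this set:

Compound 1, `C[C@@H](Cn1ccc(-c2ccc(C#N)c(Cl)c2)n1)NC(=O)c1ccccc1`, gives > 30000 nM in an ADME assay on PC-3 cells (Homo sapiens) for cytotoxicity, read by CCK-8 assay, with a stated time of 6 days (on this read-out higher numbers stand for weaker inhibition and lower numbers for stronger inhibition), a limit of the assay.
Compound 2, `COC(=O)/C=C/C(=O)N[C@@H](C)Cn1ccc(-c2ccc(C#N)c(Cl)c2)n1`, gives > 30000 nM in this assay, also a limit.
Compound 3, `C[C@@H](Cn1ccc(-c2ccc(C#N)c(Cl)c2)n1)NC(=O)C1CC(=O)C1`, gives > 30000 nM in this assay, again a limit.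

Compound 3 thus stands at the ceiling of what this assay reports, and so do its two neighbours; (the limit of > 30000 nM in this assay, at which 3 of the 3 values shown sit). The steps that reach it are unreadable: a step that the two limits leave unreadable from compound 1 to compound 3 and a step that the two limits leave unreadable from compound 2 to compound 3, and the remaining step that the two limits leave unreadable from compound 1 to compound 2 is unreadable as well. Nothing measured here separates the three amides.

Compound 4, `C[C@@H](Cn1ccc(-c2ccc(C#N)c(Cl)c2)n1)NS(=O)(=O)c1cn(C)cn1`, takes the series one place further: (1-methyl-1H-imidazol-4-yl)sulfonyl in place of (3-oxocyclobutyl)carbonyl on an amine nitrogen. Going by the values given here, no measured step bears on an exchange of a carbonyl for a sulfonyl on this amine nitrogen, and the only guide is that every amide in the set sits at the limit in this assay. Compound 3 to compound 4 is therefore expected to show no readable step, a number no higher from compound 3 to compound 4 (the limit leaves the size open), and compound 4 is expected to remain at or near the limit, estimated at 30000 nM with a range from 10000 nM to 100000 nM.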

Compound 4, half-maximal inhibitory concentration: > 30000 nM
Compound 4 ended at the assay's limit (the forecaster's own chance of this, stated with the estimate: 80%); the middle value sits exactly at the limit.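

Compound 4 gives > 30000 nM in this assay, a limit of the assay. Its steps from compound 1, compound 2 and compound 3 therefore cannot be read: the limit of > 30000 nM in this assay, at which 4 of the 4 values shown sit. The compounds shown leave open how far these four lie from one another, and whether any group on this amine nitrogen brings a value under the limit.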